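This account rests on a few compounds, and the source may have more. Where it says the series, first, only, none or still open, it means among the compounds named here.

Of the compounds shown here, three have been measured in a functional assay on MDA-MB-436 cells (Homo sapiens) for antiproliferative activity, read by MTT assay, with a stated time of 24 h; a lower number here means a stronger inhibitor, a higher number a weaker inhibitor. Compound 1 `O=C(O)CC(NS(=O)(=O)c1cc(F)cc(F)c1)c1ccccc1` gives 69400 nM and compound 2 `N#Cc1ccc(S(=O)(=O)NC(CC(=O)O)c2ccccc2)cc1` gives 59300 nM, two values that lie within the usual scatter of each other. Compound 3 `CC(C)(C)c1ccc(C(CC(=O)O)NC(=O)c2ccc(F)cc2)cc1` gives > 100000 nM, and this is a limit of the assay, not a number. Compound 3 therefore stands at the limit of > 100000 nM in this assay, at which 1 of the 3 values shown sits.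

Compound 4 `COc1ccc(C(=O)NC(CC(=O)O)c2ccc(C(C)(C)C)cc2)cc1` keeps all of compound 3 except for one substituent: methoxy in place of fluoro on an aromatic carbon. In words, methoxy takes the place of fluoro on an aromatic carbon, para to a large group, so that a 4-fluorophenyl becomes a 4-methoxyphenyl.

For the measured compounds named here, no measured pair of compounds shows this swap, so the data give no direct guide to its size in this assay. Compound 3 also offers only a limit as a starting point, not an exact number. The estimated step of an at least 1.1-fold lower number from compound 3 to compound 4 (0.04 log units; that floor lies within the scatter) is expected to be small, with no clear direction, and the assay may well report only a limit again. For compound 4 the expected value is 90000 nM, with an estimated range from 40000 nM to 200000 nM.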

Compound 4, half-maximal inhibitory concentration: > 100000 nM
Compound 4: only a limit was reported; the forecaster's own chance of this, stated with the estimate: 50%; middle value at least 1.1-fold (0.04 log units) from the limit.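

In this assay compound 4 gives > 100000 nM, which is a limit of the assay and not a number. Compound 3 also has only a limit, so no step between compound 3 and compound 4 can be read: the limit of > 100000 nM in this assay, at which 2 of the 4 values shown sit.

The compounds shown leave open whether methoxy in place of fluoro changes activity at all, and in which direction.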